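This account rests on a few compounds, and the source may have more. Where it says the series, first, only, none or still open, it means among the compounds named here.

Measured in a functional assay on SW480 cells (Homo sapiens) for inhibition; a higher number here means a weaker inhibitor, a lower number a stronger inhibitor:
- compound 1 `COc1cc[nH]c1/C=C1\C(=O)Nc2ccc(F)c(C#C[C@@H](C)O)c21` gives 130 nM
- compound 2 `COc1cc[nH]c1/C=C1\C(=O)Nc2ccc(F)c(C#C[C@@H](N)[C@@H](C)O)c21` gives 210 nM
- compound 3 `CN[C@H](C#Cc1c(F)ccc2c1/C(=C/c1[nH]ccc1OC)C(=O)N2)[C@@H](C)O` gives 140 nM

Compound 1 has the lowest of the three numbers, but neither of its neighbours lies beyond the scatter: the step of a 1.6-fold higher number from compound 1 to compound 2 (0.21 log units; within the scatter) and the step of a 1.1-fold higher number from compound 1 to compound 3 (0.03 log units; within the scatter) are both within it, as is the step of a 1.5-fold lower number from compound 2 to compound 3 (0.18 log units; within the scatter). The three compounds therefore share a common potency band in this assay.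

Compound 4 `COc1cc[nH]c1/C=C1\C(=O)Nc2ccc(F)c(C#C[C@@H]3C[C@@H](O)CN3)c21` has not been measured. It differs from compound 1 at the carbon of the triple bond that carries the side group:

4-hydroxypyrrolidin-2-yl in place of 1-hydroxyethyl on a triple-bonded carbon

The measured steps that bear on this change are those in which the 1-hydroxyethyl group of compound 1 gained an amine, to give 1-amino-2-hydroxypropyl in compound 2 and 2-hydroxy-1-(methylamino)propyl in compound 3. Both kept the number within the scatter of compound 1. Among the measured compounds shown here, the 4-hydroxypyrrolidin-2-yl group likewise keeps a nitrogen and a hydroxyl beside the triple bond, now tied into a ring, a change for which no measured pair exists. Compound 4 is therefore expected to stay close to compound 1, with the step of a 1.3-fold higher number from compound 1 to compound 4 (0.12 log units; within the scatter) not expected to exceed the scatter. The estimate for compound 4 is 170 nM, with a range from 70 nM to 450 nM.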

Compound 4, half-maximal inhibitory concentration: 44 nM
Compound 4: middle estimate off by 3.9-fold (0.59 log units), on the high side, outside the stated range (below it).
By their numbers in this assay, from the lowest: compound 4; then compounds 1, 3 and 2 (each within the scatter of the next).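

In this assay, among the compounds shown here, the 4-hydroxypyrrolidin-2-yl group gives the only steps at this triple-bonded carbon that lie beyond the scatter: a 3.0-fold lower number from compound 1 to compound 4 (0.47 log units; beyond the scatter), a 3.2-fold lower number from compound 3 to compound 4 (0.50 log units; beyond the scatter) and a 4.8-fold lower number from compound 2 to compound 4 (0.68 log units; beyond the scatter), all modest, which makes compound 4 the most potent of the four. The open-chain groups of compound 2 and compound 3 also carry a nitrogen and a hydroxyl, yet neither moved beyond the scatter of compound 1, so among these compounds the two atoms alone do not go with a stronger number, while the same atoms held in a five-membered ring do. Nothing measured here accounts for this difference.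

The compounds shown leave open whether the ring nitrogen or the ring hydroxyl matters more, a question that a plain pyrrolidin-2-yl group or a cyclopentyl ring bearing the hydroxyl would address. They also leave open how a six-membered piperidinyl ring, a methyl on the ring nitrogen or the other stereoisomers of the 4-hydroxypyrrolidin-2-yl group would read in this assay.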